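The source may hold more compounds than are shown below. What is called first, only, known or untested is meant among the compounds shown, and "the series" means these compounds.

Measured so far in a functional assay on MKN-74 cells (Homo sapiens) for antiproliferative activity, with a stated time of 24 h; on this read-out higher numbers stand for weaker inhibition and lower numbers for stronger inhibition:
- compound 1 `NC(=O)c1c(NC(=O)c2ccccc2Cl)sc2c1CCN(C(=S)Nc1ccccc1)C2` gives 15600 nM
- compound 2 `NC(=O)c1c(NC(=O)c2ccccc2Cl)sc2c1CCN(C(=O)Nc1ccccc1Cl)C2` gives 16300 nM
- compound 3 `NC(=O)c1c(NC(=O)c2ccccc2Cl)sc2c1CCN(C(=S)Nc1ccccc1Br)C2` gives 10800 nM

Compound 3 carries the lowest of the three numbers, but the steps of a 1.4-fold lower number from compound 1 to compound 3 (0.16 log units; within the scatter) and a 1.5-fold lower number from compound 2 to compound 3 (0.18 log units; within the scatter) both sit within the scatter, so the three compounds are not separated in this assay.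

Compound 4 `CSc1ccccc1NC(=S)N1CCc2c(sc(NC(=O)c3ccccc3Cl)c2C(N)=O)C1` differs from compound 3 by methylsulfanyl in place of bromo on an aromatic carbon. Within the data shown here, the only measured step at the same position is a 1.4-fold lower number from compound 1 to compound 3 (0.16 log units; within the scatter), which stayed within the scatter; no measured compound carries methylsulfanyl, so the new group itself has no precedent here. On that basis no step beyond the scatter is expected, and the step of a 1.1-fold higher number from compound 3 to compound 4 (0.05 log units; within the scatter) is estimated as essentially flat. Compound 4 is accordingly expected at 12000 nM, with a range of 5000 nM to 30000 nM.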

Compound 4, half-maximal inhibitory concentration: 13800 nM
For compound 4 the middle estimate is 1.2-fold (0.06 log units) below the measured one, within the range that was stated.
By their numbers in this assay, from the lowest: compounds 3, 4, 1 and 2 (each within the scatter of the next).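

At this aromatic carbon, a third substituent now gives no separation in this assay: methylsulfanyl against bromo gives a 1.3-fold higher number from compound 3 to compound 4 (0.11 log units; within the scatter), and methylsulfanyl against hydrogen gives a 1.1-fold lower number from compound 1 to compound 4 (0.05 log units; within the scatter). The larger group exchange on the ring amine nitrogen also stays flat, with a 1.2-fold lower number from compound 2 to compound 4 (0.07 log units; within the scatter). No supporting data bear on this result.

On these data alone, whether an amine or a carboxylic acid at this aromatic carbon would move the number beyond the scatter remains open. So does whether changes elsewhere on the shared core would separate these compounds.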